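Cytotoxicity in the bicyclic amine series: ethoxy on the thiophene

The source may report more compounds than this note shows. Statements on the series, on what has been measured and on what is new or still open speak of the compounds shown alone.

Measured compounds and their values in an ADME assay on MDCK cells (Canis lupus familiaris) for cytotoxicity, read by microscopy, with a stated time of 48 h; on this read-out higher numbers stand for lower toxicity in this test and lower numbers for higher toxicity in this test:
compound 1 `CCc1ccsc1CN[C@@H]1C[C@H]2C[C@@H]([C@H]1C)C2(C)C` gives 25000 nM
compound 2 `C[C@H]1[C@H](NCc2sccc2-c2ccccc2)C[C@H]2C[C@@H]1C2(C)C` gives 12500 nM
compound 3 `C[C@H]1[C@H](NCc2cccs2)C[C@H]2C[C@@H]1C2(C)C` gives 25000 nM

Compound 3 stands level with compound 1 at the digits printed, and together these two hold the highest of the three numbers; compound 2 lies nearest below, and the gap from compound 2 to compound 3 is a 2.0-fold higher number from compound 2 to compound 3 (0.30 log units; within the scatter), within the scatter. Nothing among the three separates beyond the scatter.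

Compound 4 `CCOc1ccsc1CN[C@@H]1C[C@H]2C[C@@H]([C@H]1C)C2(C)C` differs from compound 3 by ethoxy in place of hydrogen on an aromatic carbon. Among the compounds with values here, the steps that bear on this change are those at the same aromatic carbon: no change at the digits printed from compound 1 to compound 3 (within the scatter) and a 2.0-fold lower number from compound 1 to compound 2 (0.30 log units; within the scatter), both within the scatter. Neither an ethyl nor a phenyl at this carbon moved the read-out beyond the scatter, so an ethoxy there is expected to leave this assay unchanged as well; the step of no change at the digits printed from compound 3 to compound 4 (within the scatter) is the expected outcome for compound 4. Compound 4 is estimated at 25000 nM, with a range from 12500 nM to 50000 nM.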

Compound 4, minimum cytotoxic concentration: 50000 nM
Beside the measured number, compound 4's estimate is 2.0-fold (0.30 log units) below it; the range from low to high includes it.
By their numbers in this assay, from the lowest: compounds 2, 1, 3 and 4 (each within the scatter of the next, the first and the last beyond it).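

Ethoxy on this aromatic carbon, two ring bonds from the ring sulfur, stays within the scatter of both hydrogen and ethyl in this assay: the readings are a 2.0-fold higher number from compound 3 to compound 4 (0.30 log units; within the scatter) and a 2.0-fold higher number from compound 1 to compound 4 (0.30 log units; within the scatter) for the swap from ethyl. Against phenyl at the same carbon, however, ethoxy gives the first step in the series to pass beyond the scatter, a 4.0-fold higher number from compound 2 to compound 4 (0.60 log units; beyond the scatter), though the step is only modest. The substituent at this carbon therefore separates the series only at its two ends, ethoxy and phenyl, with compound 1 and compound 3 within the scatter of both. No measurement here accounts for that separation.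

Going by these compounds, whether the oxygen of ethoxy matters stays open, since a propyl group at this carbon would be needed to test it. A methoxy, a longer alkoxy chain or an amine there also remains untested in the compounds shown.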